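This account rests on a few compounds, and the source may have more. Where it says the series, first, only, none or still open, it means among the compounds named here.

Compound 1 `CNC(=O)c1cc(Oc2ccc(C3=NNC(c4cccc(Cl)c4Cl)C3)cc2)ccn1`: 12100 nM
Compound 2 `CNC(=O)c1cc(Oc2ccc(C3=NN(C(N)=S)C(c4cccc([N+](=O)[O-])c4)C3)cc2)ccn1`: > 50000 nM
Compound 3 `CNC(=O)c1cc(Oc2ccc(C3=NN(C(N)=S)C(c4ccc(Cl)cc4)C3)cc2)ccn1`: > 50000 nM

In a functional assay on A549 cells (Homo sapiens) for cytotoxicity, read by MTT assay, with a stated time of 72 h (on this read-out lower numbers stand for stronger inhibition and higher numbers for weaker inhibition), compound 3 gives only a limit, > 50000 nM. Compound 2 gives the same limit, so the picture is the limit of > 50000 nM in this assay, at which 2 of the 3 values shown sit. Compound 4 `CNC(=O)c1cc(Oc2ccc(C3=NN(C(N)=S)C(c4cccc(Cl)c4Cl)C3)cc2)ccn1` differs from compound 3 by one change, 2,3-dichlorophenyl in place of 4-chlorophenyl on a saturated ring carbon. Among the compounds with values here, the one measured step at that carbon is a step that the two limits leave unreadable from compound 2 to compound 3, so it sets no expected size. Compound 1 also carries 2,3-dichlorophenyl and gives a true number, 12100 nM, so a modest move towards stronger inhibition in this assay is expected. For compound 4, another limit remains quite possible. The expected step is an at least 1.6-fold lower number from compound 3 to compound 4 (0.22 log units; that floor lies within the scatter). For compound 4 the estimate is 30000 nM, within an estimated range from 10000 nM to 60000 nM.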

Compound 4, half-maximal inhibitory concentration: > 50000 nM
Compound 4 was reported as a limit (the forecaster's own chance of this, stated with the estimate: 45%); middle value at least 1.6-fold (0.22 log units) away from the limit.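

In this assay compound 4 gives only a limit, > 50000 nM. The steps among compound 2, compound 3 and compound 4 cannot be read, so 2,3-dichlorophenyl on the saturated ring carbon brings no readable change, and the values gather at one limit: the limit of > 50000 nM in this assay, at which 3 of the 4 values shown sit.

Within the data shown here, with 2,3-dichlorophenyl held fixed, the group of 3 heavy atoms in place of a hydrogen atom on the amine nitrogen in a ring gives an at least 4.1-fold higher number from compound 1 to compound 4 (0.61 log units; beyond the scatter), so this nitrogen, not the saturated ring carbon, marks the one true number.

Going by these compounds, how the 4-chlorophenyl and 3-nitrophenyl groups would read with a hydrogen atom on that nitrogen stays open. So does how an acetyl group there would read in this assay.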